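Solubility Along a Quinolone-Chalcone Series: Aryl Swap

The compounds below may be only part of what the source reports. "The series", "measured", "known", "first", "only" and "open" are said of these compounds alone.

Compound 1 `O=C(CN1CCN(c2cc3c(cc2F)c(=O)c(C(=O)O)cn3C2CC2)CC1)Nc1ccc(C(=O)/C=C/c2ccccc2Cl)cc1`: 2.45 ug/mL
Compound 2 `O=C(CN1CCN(c2cc3c(cc2F)c(=O)c(C(=O)O)cn3C2CC2)CC1)Nc1ccc(C(=O)/C=C/c2ccc(Cl)cc2)cc1`: 2.77 ug/mL

In a physicochemical assay for solubility, at pH 6.9 (a lower number here means a less soluble compound, a higher number a more soluble compound), compound 1 gives the lower of the two numbers shown, with compound 2 giving a number within the scatter of it: a 1.1-fold higher number from compound 1 to compound 2 (0.05 log units; within the scatter). Compound 3 `Cc1ccc(/C=C/C(=O)c2ccc(NC(=O)CN3CCN(c4cc5c(cc4F)c(=O)c(C(=O)O)cn5C4CC4)CC3)cc2)c(C)c1` is not yet measured; it differs from compound 1 in one place (2,4-dimethylphenyl in place of 2-chlorophenyl on a double-bonded chain carbon bound to a double-bonded chain carbon). For the measured compounds named here, no measured step covers this change. Going by the values given here, the only known step, from compound 1 to compound 2, alters the same place and stays within the scatter, so the expected step is a 1.2-fold lower number from compound 1 to compound 3 (0.09 log units; within the scatter), none beyond the scatter. Compound 3 is estimated at 2 ug/mL, between 0.8 ug/mL and 5 ug/mL.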

Compound 3, solubility: 2.12 ug/mL
Estimate against measurement, compound 3: 1.1-fold (0.03 log units) below; measured number inside the range.
By their numbers in this assay, from the lowest: compounds 3, 1 and 2 (each within the scatter of the next).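

In this assay, with 2,4-dimethylphenyl in place of 2-chlorophenyl, a 1.2-fold lower number from compound 1 to compound 3 (0.06 log units; within the scatter) is seen, and with it in place of 4-chlorophenyl, a 1.3-fold lower number from compound 2 to compound 3 (0.12 log units; within the scatter) is seen. So a group without chlorine also stays within the scatter of both chlorinated groups at this place on the chain. Nothing available explains this result. Every group shown is a phenyl ring carrying only chlorine or methyl, so it remains open whether an amine or a carboxylic acid on that ring would give a step beyond the scatter.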